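A few compounds are considered here, and "the series" means these few. Any claim that something is new, unique, unknown or untested is made for them only; others in the source may bear on it.

Three compounds of this study share one core, a cyclobutenedione bearing two aryl groups. Compound 1 `COc1cc(-c2c(-c3ccc4cc[nH]c4c3)c(=O)c2=O)cc(OC)c1OC` and compound 2 `COc1cc(-c2c(-c3ccc4[nH]ccc4c3)c(=O)c2=O)cc(OC)c1OC` carry an indole-type ring; in a functional assay on MCF7 cells (Homo sapiens) for inhibition, read by MTT assay, with a stated time of 72 h (on this read-out higher numbers stand for weaker inhibition and lower numbers for stronger inhibition), compound 1 gives "not determined" (no result reported), and compound 2 gives "not determined" (no result reported), so for both no result was reported. Going by the values given here, compound 3 `COc1ccc(-c2c(-c3cc(OC)c(OC)c(OC)c3)c(=O)c2=O)cc1N` is therefore the only one with a number: in this assay compound 3 gives 164 nM. The next compound, compound 4 `COc1ccc(-c2c(-c3cc(OC)c(OC)c(OC)c3)c(=O)c2=O)cc1O`, differs from compound 3 in one place: hydroxy in place of amino on an aromatic carbon. Among the compounds with values here, no measured pair shows this change, so the expectation rests on compound 3 alone. A step of little size is expected, a 1.3-fold lower number from compound 3 to compound 4 (0.10 log units; within the scatter), in either direction and not beyond the scatter. Compound 4 is thus estimated at 130 nM, with a range from 40 nM to 420 nM.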

Compound 4, half-maximal inhibitory concentration: 6 nM
Estimate against measurement, compound 4: 22-fold (1.34 log units) above, outside the stated range (below it).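

In this assay, hydroxy in place of amino gives a 27-fold lower number from compound 3 to compound 4 (1.44 log units; beyond the scatter) and this shows that the position, ortho to a methoxy group, responds strongly to the exchange of a single heavy atom, even though the count of hydrogen-bond donors and acceptors stays the same. Nothing available here accounts for a step of this size. The compounds shown leave open whether another group at this place, such as a methyl, a fluorine or an acetamide, would keep the low number of compound 4. They also leave open whether this change would act alike with a different second aryl group on the shared core.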